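Aryl ring substitution in a pyridinylpiperazine oxime series

A few compounds are considered here, and "the series" means these few. Any claim that something is new, unique, unknown or untested is made for them only; others in the source may bear on it.

Measured so far:
compound 1, `O/N=C(\CCN1CCN(c2ccccn2)CC1)c1ccccc1`: 70%
compound 2, `Cc1ccccc1/C(CCN1CCN(c2ccccn2)CC1)=N\O`: 72%

In a functional assay on HEK293 cells with D(4) dopamine receptor (Homo sapiens) as the target, read by FLIPR (on this read-out higher numbers stand for larger maximal responses and lower numbers for smaller maximal responses), compound 1 gives 70%, and in this assay compound 2 gives 72%; the two numbers lie within the scatter of each other, so the pair shows no separation between the unsubstituted and the methylated aryl ring. Going by the values given here, no step between measured compounds is available for this pair.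

Compound 3, `O/N=C(\CCN1CCN(c2ccccn2)CC1)c1cccc(Cl)c1`, is not yet measured in this assay. It differs from compound 1 as follows: chloro in place of hydrogen on an aromatic carbon.

Among the compounds with values here, with only two measured compounds, both at the same level, the step of a number 2 percentage points higher from compound 1 to compound 3 (within the scatter) in this assay is expected to be small and within the scatter in either direction. Compound 3 is therefore expected to reach 72% in this assay, estimated within 55% to 90%.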

Compound 3, largest response reached (reported as efficacy), in percent of the reference or control that the assay uses: 73%
Beside the measured number, compound 3's estimate is 1 percentage points below it; the range from low to high includes it.
By their numbers in this assay, from the lowest: compounds 1, 2 and 3 (each within the scatter of the next).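

In this assay, chloro in place of hydrogen on an aromatic carbon, meta to a large group, gives a number 3 percentage points higher from compound 1 to compound 3 (within the scatter) and so stays within the scatter. This is the first step in the series that can be read at a single place, as the pair of compound 1 and compound 2 came with no listed step. Phenyl to 3-chlorophenyl leaves the maximal response of compound 3 unseparated from that of compound 1, so a chlorine atom at this position is tolerated on this read-out. Nothing at hand bears on why the two numbers stay level.

Open, on these data alone, is whether the level holds with a group of another kind at this position, such as an amine, a carboxylic acid or a longer chain. One chloro step also cannot tell whether chloro on another carbon of the ring would read the same.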